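Phenyl to 1,3-thiazol-2-yl: Does Stability Hold?

The source may report more compounds than this note shows. Statements on the series, on what has been measured and on what is new or still open speak of the compounds shown alone.

Three compounds have been run in an ADME assay on microsomes from liver (Mus musculus) for metabolic stability, read by LC-MS, with NADPH named in the record, with a stated time of 60 min, tested at 1 uM, in the absence of a further agent; on this read-out higher numbers stand for a more stable compound and lower numbers for a less stable compound. Compound 1 `COc1ccc(-c2c(C)oc3c(N4CC[C@@H](NC(C)=O)C4)cc(C)nc23)cc1OC` returns only the limit of the assay, > 95%. Compound 2 `CC(=O)N[C@@H]1CCN(c2cc(C)nn3c(-c4ccccc4)c(C)nc23)C1` likewise returns only a limit, > 95%. Compound 3 `CC(=O)N[C@@H]1CCN(c2cc(C)nn3c(-c4cccc(S(=O)(=O)N(C)C)c4)c(C)nc23)C1` again gives only the limit, > 95%. Going by the values given here, the single one-place step, a step that the two limits leave unreadable from compound 2 to compound 3, cannot be sized, because of the limit of > 95% in this assay, at which 3 of the 3 values shown sit. Compound 2 thus stands at the limit shared by every value shown. Compound 4 `CC(=O)N[C@@H]1CCN(c2cc(C)nn3c(-c4nccs4)c(C)nc23)C1` differs from it in one place: 1,3-thiazol-2-yl in place of phenyl on an aromatic carbon. Among the compounds with values here, no measured step speaks to this change, so from compound 2 to compound 4 a step of a number at least 2 percentage points lower from compound 2 to compound 4 (that floor lies within the scatter) is expected, none beyond the scatter. Compound 4 is therefore estimated at 93%, between 80% and 99%.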

Compound 4, percent of the compound remaining: > 95%
Compound 4: only a limit was reported (the forecaster's own chance of this, stated with the estimate: 60%); middle value at least 2 percentage points away from the limit.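

The step from compound 2 to compound 4 cannot be read, because both values are limits and not numbers: the limit of > 95% in this assay, at which 4 of the 4 values shown sit.

As far as these compounds go, whether 1,3-thiazol-2-yl in place of phenyl changes stability at all, and how these four compounds rank against one another, stays open.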